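A few compounds are considered here, and "the series" means these few. Any claim that something is new, unique, unknown or untested is made for them only; others in the source may bear on it.

Compound 2 `COc1cncc(C2C(C#N)=C(N)Oc3cc(OC)ccc32)c1` and compound 1 `COc1ccc2c(c1)OC(N)=C(C#N)C2c1cccc(Br)c1` share one core and differ only in the aromatic ring attached to it. In a functional assay on T47D cells (Homo sapiens) for activation (on this read-out lower numbers stand for an effect already at smaller amounts and higher numbers for an effect only at larger amounts of compound), compound 2 gives 47000000 nM. In this assay compound 1 gives 52000000 nM. These two numbers lie within the scatter of each other, so neither compound can be set apart from the other on this read-out; compound 2 simply has the lower of the two numbers, with compound 1 the nearer and only neighbour. Compound 3 `COc1ccc2c(c1)OC(N)=C(C#N)C2c1cccnc1` has not been measured. It differs from compound 2 by hydrogen in place of methoxy on an aromatic carbon, a hydrogen in place of methoxy on an aromatic carbon. No pair of measured compounds that differ in only one place is at hand, so the size of such a step cannot be read off from the numbers shown. Among the measured compounds shown here, the only guide is that compound 1 and compound 2, with different aromatic rings on the core, gave numbers within the scatter of each other. The expected step is therefore a 1.1-fold higher number from compound 2 to compound 3 (0.03 log units; within the scatter), none beyond the scatter. Compound 3 is accordingly estimated at 50000000 nM in this assay, with a range from 15000000 nM to 160000000 nM.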

Compound 3, half-maximal effective concentration: 170000000 nM
For compound 3 the middle estimate is 3.4-fold (0.53 log units) below the measured one; the measured number lies above the stated range.
By their numbers in this assay, from the lowest: compounds 2 and 1 (each within the scatter of the next); then compound 3.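

Among the compounds shown here, on the ring with one nitrogen, the methoxy group two atoms from the ring nitrogen turns out to matter in this assay: taking it away gives a 3.6-fold higher number from compound 2 to compound 3 (0.56 log units; beyond the scatter), a modest change but the first single-place step here that clears the scatter. The bare pyridin-3-yl ring also stands apart from 3-bromophenyl on the shared core, with a 3.3-fold higher number from compound 1 to compound 3 (0.51 log units; beyond the scatter), so a difference in the aromatic ring does show on this read-out, although compound 1 and compound 2 could not be separated. No measurement at hand bears on why these steps have this size.

The compounds shown leave open whether the effect belongs to methoxy itself or would also appear with another group at this place, such as a hydroxyl, an ethoxy, an amine or a chlorine. They also leave open whether a methoxy group at the corresponding place on the 3-bromophenyl ring, or a bromine on the pyridine ring, would shift the number in the same direction.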